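The source may hold more compounds than are shown below. What is called first, only, known or untested is meant among the compounds shown, and "the series" means these compounds.

Compound 1 `CNc1cc(Oc2ccc(NC(=O)Nc3cccc(C(F)(F)F)c3)c(F)c2F)ncn1`: 20 nM
Compound 2 `O=C(Nc1ccc(Oc2ccncn2)cc1)Nc1cccc(C(F)(F)F)c1`: 160 nM
Compound 3 `CNc1cc(Oc2cc(C)c(NC(=O)Nc3cccc(C(F)(F)F)c3)cc2C)ncn1`: 32 nM

Three compounds sharing a diaryl urea core have been examined in an assay on isolated protein for inhibition of serine/threonine-protein kinase TNNI3K (Homo sapiens); on this read-out lower numbers stand for stronger inhibition and higher numbers for weaker inhibition. Compound 2 `O=C(Nc1ccc(Oc2ccncn2)cc1)Nc1cccc(C(F)(F)F)c1` stands with the highest number of the three, at 160 nM in this assay. Its nearest neighbour is compound 3, whose value of 32 nM is lower by a margin beyond the usual scatter, and compound 1 lies further away still, at 20 nM. Compound 2 is the only one of the three that carries no additional group on its core, whereas compounds 1 and 3 are both more elaborated and both give lower numbers.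

The next compound, compound 4 `CN(C)c1cc(Oc2ccc(NC(=O)Nc3cccc(C(F)(F)F)c3)cc2)ncn1`, is reached from compound 2 by a single change: dimethylamino in place of hydrogen on an aromatic carbon. Among the measured compounds shown here, no directly comparable pair of measured compounds exists for this exact change, so the size of the step must be inferred. Because compound 2 gives 160 nM while the more substituted compound 1 gives 20 nM and compound 3 gives 32 nM, the step is expected to lower the number in this assay, by a modest amount that is still beyond the scatter. The expected step is a 3.2-fold lower number from compound 2 to compound 4 (0.51 log units; beyond the scatter). Compound 4 is accordingly estimated at 50 nM, within a range of 15 nM to 160 nM.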

Compound 4, half-maximal inhibitory concentration: 2500 nM
Compound 4: middle estimate off by 50-fold (1.70 log units), on the low side, and the stated range ends below it.
By their numbers in this assay, from the lowest: compounds 1 and 3 (each within the scatter of the next); then compound 2; then compound 4.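

In this assay, among the compounds shown here, replacing pyrimidin-4-yl with 6-(dimethylamino)pyrimidin-4-yl on the shared core gives a 16-fold higher number from compound 2 to compound 4 (1.19 log units; beyond the scatter), the first comparison in this set that changes one place only, and it shows that this aromatic carbon is sensitive to substitution and that dimethylamino there goes with markedly weaker inhibition. Compounds 1 and 3 also carry a nitrogen substituent on this ring, in the form of methylamino, and give lower numbers, but both differ from compound 4 in more than one place, so they cannot be read as steps against it and the effect of dimethylamino stands on this single pair. Nothing available here speaks to the reason for the rise.

Still open, from the compounds shown here alone, is whether methylamino or a plain amine on this same carbon, with the rest of compound 2 unchanged, would raise the number as dimethylamino does or lower it. Also open, going by these compounds, is whether a group without nitrogen, such as methoxy or methyl, would be tolerated at this position, and whether the fluorine or methyl groups seen on the core of compounds 1 and 3 would alter the size of this step.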